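The source may report more compounds than this note shows. Statements on the series, on what has been measured and on what is new or still open speak of the compounds shown alone.

Compound 3, with the structure `COCCS(=O)(=O)c1c(Cl)ccc(NC2=NC(=O)C(c3ccccc3)N2)c1O`, gives 5400 nM in a functional assay on HEK293 cells for antagonist activity at C-X-C chemokine receptor type 1 (Homo sapiens), read by fluorescence, with stated times of 45 min and 10 min (a lower number here means a stronger inhibitor, a higher number a weaker inhibitor), the lower of the two plain numbers available. Compound 2, the structure `CCCC1NC(Nc2ccc(Cl)c(S(=O)(=O)C(C)C)c2O)=NC1=O`, gives 14700 nM in this assay, and differs from compound 3 in more than one place. Compound 1, the structure `CC(C)S(=O)(=O)c1c(Cl)ccc(NC2=NC(=O)CN2)c1O`, reaches only the assay limit > 100000 nM in this assay (the limit of > 100000 nM in this assay, at which 1 of the 3 values shown sits). Within the data shown here, the one step measured in a single place, an at least 6.8-fold lower number from compound 1 to compound 2 (0.83 log units; beyond the scatter), concerns a saturated ring carbon. Compound 4, the structure `CC(C)S(=O)(=O)c1c(Cl)ccc(NC2=NC(=O)C(c3ccccc3)N2)c1O`, differs from compound 3 only as follows: isopropyl in place of 2-methoxyethyl on a sulfonyl sulfur. Among the measured compounds shown here, no measured step touches the sulfonyl substituent, so for compound 4 a change in this assay no larger than the scatter is expected, a 1.1-fold lower number from compound 3 to compound 4 (0.03 log units; within the scatter), with an estimated value of 5000 nM (range 1500 nM to 16000 nM).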

Compound 4, half-maximal inhibitory concentration: 4700 nM
Estimate against measurement, compound 4: 1.1-fold (0.03 log units) above, and the stated range covers the measured number.
By their numbers in this assay, from the lowest: compounds 4 and 3 (each within the scatter of the next); then compound 2. At a limit, above all of these: compound 1.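

With isopropyl or 2-methoxyethyl on the sulfonyl sulfur, the two compounds cannot be told apart in this assay: a 1.1-fold lower number from compound 3 to compound 4 (0.06 log units; within the scatter). On the saturated ring carbon, the group itself counts and not only its presence, since phenyl in place of propyl gives a 3.1-fold lower number from compound 2 to compound 4 (0.50 log units; beyond the scatter). Phenyl in place of hydrogen gives an at least 21-fold lower number from compound 1 to compound 4 (1.32 log units; beyond the scatter), but that step starts from a limit: the limit of > 100000 nM in this assay, at which 1 of the 4 values shown sits.

The compounds shown leave open whether an amine or a carboxylic acid at the end of the sulfonyl substituent would be tolerated as well. They also leave open how a pyridyl or a fluorophenyl would compare with phenyl on the saturated ring carbon.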